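Chain-end exchange in the dienoate ester series

The source may report more compounds than this note shows. Statements on the series, on what has been measured and on what is new or still open speak of the compounds shown alone.

Two members of this series have been measured in a physicochemical assay for lipophilicity; on this read-out higher numbers stand for higher lipophilicity and lower numbers for lower lipophilicity. Compound 1 `COC(C)(C)CCCC(C)C/C=C/C(C)=C/C(=O)OCCC(C)C` gives 7.03. Within the data shown here, compound 2 `CCOC(=O)/C=C(C)/C=C/CC(C)CCCC(C)(C)Cl` gives 6.44, the lower of the two numbers, and the gap to compound 1 lies beyond the usual scatter; no single-point step between these two is defined, so their values are simply set side by side. Compound 3 `CCOC(=O)/C=C(C)/C=C/CC(C)CCC(=O)C(C)C` has not yet been measured in this assay. Relative to compound 2 it carries one change: isopropylcarbonyl in place of 2-chloro-2-methylpropyl on a saturated chain carbon, four bonds along the chain from a double-bonded chain carbon. A downward step in this assay, well beyond the scatter, is expected, since the estimate rests on the value of compound 2 6.44 together with this exchange. The step from compound 2 to compound 3 is expected to come out at a number 1.54 log units lower from compound 2 to compound 3 (beyond the scatter). For compound 3 the estimate is 4.9, with a range from 4.3 to 5.5.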

Compound 3, partition coefficient: 4.3
Estimate against measurement, compound 3: 0.60 log units above; low and high end bracket the measured number.
By their numbers in this assay, from the lowest: compound 3; then compound 2; then compound 1.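

Among these compounds, at the saturated chain carbon four bonds along the chain from a double-bonded chain carbon, isopropylcarbonyl in place of 2-chloro-2-methylpropyl gives the first single-change step in this assay (a number 2.14 log units lower from compound 2 to compound 3 (beyond the scatter)), and this step is large. Both groups hold 5 heavy atoms and no ring, so the read-out at this position moves strongly on an exchange that leaves the heavy-atom count unchanged while removing chlorine and adding one hydrogen-bond acceptor. Nothing measured in support accounts for the size of this step.

The compounds shown leave open whether the step follows the loss of the chlorine or the entry of the carbonyl. A plain 2-methylpropyl group, a hydroxyl group or an amine on the same chain carbon would help separate the two.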